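This account rests on a few compounds, and the source may have more. Where it says the series, first, only, none or still open, it means among the compounds named here.

In a functional assay on SMMC-7221 cells (Homo sapiens) for antiproliferative activity, read by MTT assay, with a stated time of 48 h (on this read-out higher numbers stand for weaker inhibition and lower numbers for stronger inhibition), the measured compounds read:

Compound 1 `CCNC(=O)Nc1nc(-c2ccc(OCC)cc2)c(-c2cc(OC)c(OC)c(OC)c2)s1`: 10.6 nM
Compound 2 `CCOc1ccc(-c2nc(NS(=O)(=O)c3ccccc3C(F)(F)F)sc2-c2cc(OC)c(OC)c(OC)c2)cc1`: > 5000 nM, a limit
Compound 3 `CCOc1ccc(-c2nc(NS(=O)(=O)c3ccc([N+](=O)[O-])cc3OC)sc2-c2cc(OC)c(OC)c(OC)c2)cc1`: > 5000 nM, a limit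

Compound 3 has no number, only a limit: it sits at the limit of > 5000 nM in this assay, at which 2 of the 3 values shown sit. Compound 4 `CCOc1ccc(-c2nc(NS(=O)(=O)c3ccc(OC)c(F)c3)sc2-c2cc(OC)c(OC)c(OC)c2)cc1` differs from it as follows: 3-fluoro-4-methoxyphenyl in place of 2-methoxy-4-nitrophenyl on a sulfonyl sulfur. In words, 3-fluoro-4-methoxyphenyl takes the place of 2-methoxy-4-nitrophenyl on a sulfonyl sulfur. For the measured compounds named here, the one measured step that bears on this change at that place is a step that the two limits leave unreadable from compound 2 to compound 3, so it offers no size to carry over. Compound 4 is therefore expected to stay close to that limit in this assay, with no readable change in either direction. The expected step is a number no higher from compound 3 to compound 4 (the limit leaves the size open). For compound 4 the estimated value is 5000 nM, with an expected range of 800 nM to 20000 nM.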

Compound 4, half-maximal inhibitory concentration: > 5000 nM
Compound 4: a limit, no number; the forecaster's own chance of this, stated with the estimate: 60%; the middle value lies on the limit itself.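

In this assay, compound 4 joins compound 2 and compound 3 at a limit rather than a number: the limit of > 5000 nM in this assay, at which 3 of the 4 values shown sit. The steps among these three compounds cannot be read, so the change of aryl group on the sulfonyl sulfur has no measurable size. What is new is a readable step for a sulfonyl group on this nitrogen: (3-fluoro-4-methoxyphenyl)sulfonyl in place of ethylcarbamoyl gives an at least 470-fold higher number from compound 1 to compound 4 (2.67 log units; beyond the scatter).

On these data alone, how far past the limit these three compounds lie remains open. So does whether methylsulfonyl on this nitrogen, or propylcarbamoyl in place of ethylcarbamoyl, would give a measurable value.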